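From Neopentyl to 2-methylprop-1-en-1-yl at the Chain End

This account rests on a few compounds, and the source may have more. Where it says the series, first, only, none or still open, it means among the compounds named here.

Measured in a physicochemical assay for lipophilicity; a lower number here means a more polar compound, a higher number a more lipophilic compound:
- compound 1 `CC(/C=C/CC(C)CCCC(C)C)=C\C(=O)OC(C)C`: 7.15
- compound 2 `CC(/C=C/CC(C)CCCC(C)(C)OC(C)C)=C\C(=O)OC(C)C`: 6.9
- compound 3 `CC(/C=C/CC(C)CCCC(C)(C)C)=C\C(=O)OC(C)C`: 7.56

Of these three, compound 3 has the highest number, 7.56. The other two both sit lower by more than the usual scatter: a number 0.41 log units higher from compound 1 to compound 3 (beyond the scatter), and a number 0.66 log units higher from compound 2 to compound 3 (beyond the scatter).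

Compound 4 `CC(C)=CCCC(C)C/C=C/C(C)=C/C(=O)OC(C)C` has not been measured yet. It differs from compound 3 by 2-methylprop-1-en-1-yl in place of neopentyl on a saturated chain carbon, four bonds along the chain from a double-bonded chain carbon.

For the measured compounds named here, two measured steps bear on this change, and both concern the same end of the chain. The closer guide is a number 0.41 log units higher from compound 1 to compound 3 (beyond the scatter), which came with methyl in place of hydrogen on a saturated chain carbon bound to three saturated chain carbons. Read backwards, that step points to a lower number for a chain end with fewer carbons. The step of a number 0.66 log units higher from compound 2 to compound 3 (beyond the scatter) shows that a change at this end can also be modest in size. Going by the values given here, no measured step shows what a new double bond does here, so the estimate stays uncertain.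

A modest downward step is expected, and the estimated step is a number 0.71 log units lower from compound 3 to compound 4 (beyond the scatter).

For compound 4 the estimated value is 6.85, with an expected range from 6.5 to 7.2.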

Compound 4, partition coefficient: 6.6
For compound 4 the middle estimate is 0.25 log units above the measured one; low and high end bracket the measured number.
By their numbers in this assay, from the lowest: compounds 4, 2 and 1 (each within the scatter of the next, the first and the last beyond it); then compound 3.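

In this assay, the full change from neopentyl to 2-methylprop-1-en-1-yl gives a number 0.96 log units lower from compound 3 to compound 4 (beyond the scatter), the largest step among these four compounds. Isobutyl is the closest saturated counterpart of the new group here, and replacing it gives a number 0.55 log units lower from compound 1 to compound 4 (beyond the scatter), so this chain end responds to more than the loss of the outer methyl seen in the earlier steps. Compound 4 also cannot be told apart from the isopropoxy-bearing compound, with a number 0.30 log units lower from compound 2 to compound 4 (within the scatter), which shows that a chain end without any oxygen can give a reading in the same range, and nothing measured here gives the reason for these shifts.

These compounds leave open how far the double bond itself accounts for the steps, since each step also changes the shape of the chain end, and whether the result depends on where along the chain the double bond sits. They also leave open how a hydroxyl group, an amine or a longer chain at this same end would compare with 2-methylprop-1-en-1-yl.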